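The source may report more compounds than this note shows. Statements on the series, on what has been measured and on what is new or still open speak of the compounds shown alone.

Measured in a functional assay on SAS cells (Homo sapiens) for cytotoxicity, read by MTT assay, with a stated time of 48 h; a higher number here means a weaker inhibitor, a lower number a stronger inhibitor:
Compound 1 `COC(=O)[C@@H](NC(=O)CSC1=CC(=O)c2cccc(OC)c2C1=O)C(C)C`: 45000 nM
Compound 2 `CC[C@H](C)[C@H](NC(=O)CSC1=C(OC)C(=O)c2ccccc2C1=O)C(=O)OC`: 60000 nM
Compound 3 `COC(=O)[C@H](CC(C)C)NC(=O)CSC1=C(C)C(=O)c2cccc(OC)c2C1=O`: 78500 nM

Compound 2 gives 60000 nM, within the scatter of both compound 1 and compound 3, so the three cannot be ranked. The next step leads to compound 4 `COC(=O)CCCNC(=O)CSC1=C(OC)C(=O)c2ccccc2C1=O`: 3-(methoxycarbonyl)propyl in place of 1-(methoxycarbonyl)-2-methylbutyl on an amide-type nitrogen. In words, 3-(methoxycarbonyl)propyl stands in place of 1-(methoxycarbonyl)-2-methylbutyl on an amide-type nitrogen.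

No measured pair differs in one place only, so no step size is shown directly. Compound 3, at 78500 nM, and compound 1, at 45000 nM, carry other groups on that nitrogen and stay within the scatter of compound 2. No step beyond the scatter is therefore expected in this assay, in either direction. The expected change, a 1.1-fold higher number from compound 2 to compound 4 (0.03 log units; within the scatter), is small. For compound 4 the estimate is 65000 nM, with an expected range of 28000 nM to 130000 nM.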

Compound 4, half-maximal inhibitory concentration: 24500 nM
Compound 4: middle estimate off by 2.7-fold (0.42 log units), on the high side, outside the stated range (below it).
By their numbers in this assay, from the lowest: compounds 4, 1, 2 and 3 (each within the scatter of the next, the first and the last beyond it).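

In this assay, among the compounds shown here, the change on the amide-type nitrogen gives a 2.4-fold lower number from compound 2 to compound 4 (0.39 log units; beyond the scatter) and is the first step that can be read at this position, so the group there does register in this assay. The entering 3-(methoxycarbonyl)propyl has fewer heavy atoms and no defined stereocentres, with the same hydrogen-bond counts as the group it replaces. Nothing available accounts for the step.

The branching and the stereocentres change together here, so their contributions remain unseparated. Also open, going by these compounds, is how a longer chain, or a carboxylic acid in place of the methyl ester, would read at this nitrogen.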